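The compounds below may be only part of what the source reports. "The series", "measured", "known", "first", "only" and "open" are said of these compounds alone.

Two compounds of the series carry a number in an assay on isolated protein for inhibition of BDNF/NT-3 growth factors receptor (Homo sapiens); on this read-out lower numbers stand for stronger inhibition and higher numbers for weaker inhibition. Compound 1 `Cn1cc(/C=C2\C(=O)Nc3ccc(S(N)(=O)=O)cc32)c2ccccc21` gives 7.62 nM in this assay. For the measured compounds named here, compound 2 `CN(C)S(=O)(=O)c1ccc2c(c1)/C(=C/c1cn(C)c3ccc(O)cc13)C(=O)N2` gives 13.5 nM in this assay, a number that lies within the usual scatter of the one from compound 1, so the two cannot be told apart on what is known. Compound 3 `COc1ccc2c(c1)c(/C=C1\C(=O)Nc3ccc(S(=O)(=O)N(C)C)cc31)cn2C` has not yet been measured in this assay. It differs from compound 2 in a single place: methyl in place of hydrogen on an oxygen on an aromatic ring. Going by the values given here, no measured pair shows this change, and the two known values supply no step from which to read its size. The expectation is a step that stays within the scatter, leaning slightly toward a weaker read-out. The estimated step is a 1.5-fold higher number from compound 2 to compound 3 (0.17 log units; within the scatter). The estimate for compound 3 is 20 nM, with a range from 8 nM to 55 nM.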

Compound 3, half-maximal inhibitory concentration: 15.3 nM
Compound 3: the middle estimate sits 1.3-fold (0.12 log units) above what was measured, and the stated range covers the measured number.
By their numbers in this assay, from the lowest: compounds 1, 2 and 3 (each within the scatter of the next).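

The hydroxy to methoxy swap on the aromatic ring gives a 1.1-fold higher number from compound 2 to compound 3 (0.05 log units; within the scatter) in this assay, so the two compounds cannot be told apart on this read-out. For the compounds shown here, this is the first step read at this position, and on this single pair, the hydrogen on that oxygen is not required to keep the number in the range of compound 2. Nothing available explains this result.

Still open, as far as these compounds go, is whether a larger group on this oxygen, such as a longer chain or a chain ending in an amine or a carboxylic acid, is accepted as well, and what follows if a fluorine replaces the oxygen. From the compounds shown here alone, it is also open whether the same step holds with the sulfonamide of compound 1.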